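The source may report more compounds than this note shows. Statements on the series, on what has been measured and on what is new or still open speak of the compounds shown alone.

The measured compounds:
compound 1, `CCCn1c(=O)c2nc(-c3cnn(Cc4cc(F)ccc4Cl)c3)[nH]c2n(CCC)c1=O`, 4800 nM
compound 2, `CCCn1c(=O)c2nc(-c3cnn(Cc4ccccc4C)c3)[nH]c2n(CCC)c1=O`, 33 nM

Among the measured compounds shown here, in an in vitro assay on HEK293 cells for displacement of a labelled ligand from adenosine receptor A2b (Homo sapiens) (a higher number here means a weaker inhibitor, a lower number a stronger inhibitor), compound 2 gives the lowest of the two numbers, and its only neighbour is compound 1. For the measured compounds named here, the single measured step reads a 150-fold lower number from compound 1 to compound 2 (2.16 log units; beyond the scatter), a change that lies at the same place as the one now considered: a halogenated phenyl gave way to methylphenyl on the saturated chain carbon bound to the aromatic nitrogen, and the number fell sharply.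

Compound 3 is `CCCn1c(=O)c2nc(-c3cnn(Cc4c(F)cc(F)cc4F)c3)[nH]c2n(CCC)c1=O`. It differs from compound 2 by 2,4,6-trifluorophenyl in place of 2-methylphenyl on a saturated chain carbon bound to an aromatic nitrogen. The step from compound 1 to compound 2 is the only one that bears on it, and it points the other way: leaving methylphenyl for a halogen-bearing phenyl went with a large rise in the number. Compound 3 carries three fluorines and no chlorine, a pattern not among the measured compounds, so the size is uncertain, but a rise well beyond the scatter is expected in this assay. For compound 3 the expected step is a 27-fold higher number from compound 2 to compound 3 (1.44 log units; beyond the scatter). Compound 3 is thus estimated at 900 nM, within a range from 150 nM to 6000 nM.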

Compound 3, inhibition constant: 650 nM
Compound 3: the middle estimate sits 1.4-fold (0.14 log units) above what was measured; the measured number falls inside the stated range.
By their numbers in this assay, from the lowest: compound 2; then compound 3; then compound 1.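

In this assay, the step of a 20-fold higher number from compound 2 to compound 3 (1.29 log units; beyond the scatter) shows that on the saturated chain carbon bound to an aromatic nitrogen, the rise on leaving 2-methylphenyl is not tied to the chlorine of compound 1, since a phenyl bearing fluorine alone also gives a number well above that of compound 2. The step of a 7.4-fold lower number from compound 1 to compound 3 (0.87 log units; beyond the scatter) adds something that compound 1 and compound 2 alone could not show: halogen-bearing phenyl groups at this place are not equivalent, and 2,4,6-trifluorophenyl loses less than 2-chloro-5-fluorophenyl does, while compound 2 keeps the lowest number of the three. No measurement given here says why these numbers differ.

The compounds shown leave open whether the rise goes with losing the methyl group or with gaining halogen, a question that an unsubstituted phenyl or a methoxyphenyl at the same place would help to separate. Also open, going by these compounds, is whether a group other than a substituted phenyl on that carbon, such as a cyclohexyl ring or a simple ethyl chain, would hold the number as low as compound 2 does.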